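Chloro in place of tert-butyl: what to expect

The source may hold more compounds than are shown below. What is called first, only, known or untested is meant among the compounds shown, and "the series" means these compounds.

compound 1 `CCCc1cc(N)c2cc(NC(=O)/C=C/c3ccc(C(C)(C)C)cc3)ccc2n1`: 22 nM
compound 2 `CCCc1cc(N)c2cc(NC(=O)C3CCC(c4ccc(Cl)cc4)CC3)ccc2n1`: 4.4 nM
compound 3 `CCCc1cc(OC)c2cc(NC(=O)/C=C/c3ccc(C(F)(F)F)cc3)ccc2n1`: 26 nM

Of the compounds shown here, three built on a shared core have been tested in an assay on isolated protein for displacement of a labelled ligand from melanin-concentrating hormone receptor 1 (Homo sapiens); a lower number here means a stronger inhibitor, a higher number a weaker inhibitor. Among them compound 1 stands second highest. Its nearest neighbour is compound 3, and the two values lie within the scatter, so no order between them can be read. Compound 2 gives a lower number than compound 1, a gap beyond the scatter.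

Compound 4, `CCCc1cc(N)c2cc(NC(=O)/C=C/c3ccc(Cl)cc3)ccc2n1`, has not yet been measured. It differs from compound 1 in one place:

chloro in place of tert-butyl on an aromatic carbon

Going by the values given here, no measured pair shows this same change on its own, so its size has to be guessed. Compound 3 carries trifluoromethyl at that position, along with a second difference elsewhere in the core, and gives 26 nM, close to compound 1. The expected step is therefore a 1.4-fold higher number from compound 1 to compound 4 (0.13 log units; within the scatter), not beyond the scatter. For compound 4 the estimate is 30 nM, with a range from 10 nM to 90 nM.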

Compound 4, half-maximal inhibitory concentration: 6 nM
Beside the measured number, compound 4's estimate is 5.0-fold (0.70 log units) above it, and the stated range ends above it.
By their numbers in this assay, from the lowest: compounds 2 and 4 (each within the scatter of the next); then compounds 1 and 3 (each within the scatter of the next).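

With only the group on the aromatic carbon changed, chloro in place of tert-butyl gives a 3.7-fold lower number from compound 1 to compound 4 (0.56 log units; beyond the scatter) in this assay. Going by these compounds alone, this is the first direct reading of this position, and it shows that the four carbons of tert-butyl are not required for a strong number here: one chlorine atom in the same place, para to a large group, does better. Nothing measured here explains why the number falls.

As far as these compounds go, only these two groups have been compared on their own at this position, so it remains open whether the gain is particular to chloro or would also appear with fluoro or a nitrile. From the compounds shown here alone, it is also open how an amine or a carboxylic acid in that place would fare.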